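This account rests on a few compounds, and the source may have more. Where it says the series, first, only, none or still open, it means among the compounds named here.

Measured compounds, with their numbers in a functional assay on DU-145 cells (Homo sapiens) for cytotoxicity, read by MTT assay, with a stated time of 48 h; a lower number here means a stronger inhibitor, a higher number a weaker inhibitor:
compound 1 `O=C(Nc1nc2ccc(Cl)cc2s1)c1cc(-c2ccc(F)cc2)n2nc(-c3ccccc3)cc2n1`, 17600 nM
compound 2 `COc1ccc(-c2cc(C(=O)Nc3nc4ccc(Cl)cc4s3)nc3cc(-c4ccccc4)nn23)cc1`, 5880 nM
compound 3 `COc1cc(-c2cc(C(=O)Nc3nc4ccc(Cl)cc4s3)nc3cc(-c4ccccc4)nn23)cc(OC)c1OC`, 38900 nM

Compound 2 gives the lowest number of the three; the nearest neighbour is a 3.0-fold lower number from compound 1 to compound 2 (0.48 log units; beyond the scatter) and the widest gap is a 6.6-fold higher number from compound 2 to compound 3 (0.82 log units; beyond the scatter), both beyond the scatter. Compound 4 `COc1ccc(-c2cc(C(=O)Nc3nc4cc(C)c(C)cc4s3)nc3cc(-c4ccccc4)nn23)cc1` differs from compound 2 in one place: 5,6-dimethyl-1,3-benzothiazol-2-yl in place of 6-chloro-1,3-benzothiazol-2-yl on an amide-type nitrogen. Within the data shown here, none of the measured steps touches this position: a 3.0-fold lower number from compound 1 to compound 2 (0.48 log units; beyond the scatter), a 2.2-fold higher number from compound 1 to compound 3 (0.34 log units; beyond the scatter) and a 6.6-fold higher number from compound 2 to compound 3 (0.82 log units; beyond the scatter) all concern the group on an aromatic carbon, not the amide-type nitrogen. Nothing here sets a direction in this assay, so the expected step is a 1.2-fold higher number from compound 2 to compound 4 (0.08 log units; within the scatter), carrying wide uncertainty. Compound 4 is estimated at 7000 nM, range 2500 nM to 20000 nM.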

Compound 4, half-maximal inhibitory concentration: 12300 nM
The estimate for compound 4 lay 1.8-fold (0.24 log units) below the measured number; the range from low to high includes it.
By their numbers in this assay, from the lowest: compound 2; then compounds 4 and 1 (each within the scatter of the next); then compound 3.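

Unlike the earlier steps, all on the aromatic carbon, this one shows that the group on the amide-type nitrogen also moves the number in this assay: 5,6-dimethyl-1,3-benzothiazol-2-yl in place of 6-chloro-1,3-benzothiazol-2-yl gives a 2.1-fold higher number from compound 2 to compound 4 (0.32 log units; beyond the scatter). The change is read only with the 4-methoxyphenyl group of compound 2 held fixed. No available evidence accounts for this step.

Open, on these data alone, is whether the step carries over to the 4-fluorophenyl group of compound 1. Also open, as far as these compounds go, is how an amine or a carboxylic acid in place of the chlorine would read.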